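A few compounds are considered here, and "the series" means these few. Any claim that something is new, unique, unknown or untested is made for them only; others in the source may bear on it.

Measured in an ADME assay on MT4 cells (Homo sapiens) for cytotoxicity, read by MTT assay; a lower number here means that less compound is tolerated, a higher number that more compound is tolerated:
- Compound 1 `Cc1cc(C)cc(S(=O)(=O)c2c(C(=O)NCC(=O)NC(C)c3ccccc3)[nH]c3ccc(Cl)cc23)c1`: 29400 nM
- Compound 2 `Cc1cc(C)cc(S(=O)(=O)c2c(C(=O)Nc3ccnc(C#N)c3)[nH]c3ccc(Cl)cc23)c1`: 6840 nM

Of these two numbers, the lower belongs to compound 2. Compound 3 `Cc1cc(C)cc(S(=O)(=O)c2c(C(=O)NC(c3ccc(Cl)cc3)C3CC3)[nH]c3ccc(Cl)cc23)c1` differs from it on the amide-type nitrogen: a group of 11 heavy atoms (10 carbon, 1 chlorine; one three-membered non-aromatic ring of carbon only, one six-membered aromatic ring of carbon only) in place of a group of 8 heavy atoms (6 carbon, 2 nitrogen; one six-membered aromatic ring with 1 hetero atom), on an amide-type nitrogen. For the measured compounds named here, only one measured step bears on this place, a 4.3-fold lower number from compound 1 to compound 2 (0.63 log units; beyond the scatter), and it is modest but beyond the scatter. Compound 3 gives up the 2-cyanopyridin-4-yl group that came with that drop, so a modest rise of similar size is expected, though the entering group is new. The expected step is a 2.0-fold higher number from compound 2 to compound 3 (0.31 log units; beyond the scatter). For compound 3 the estimated value is 14000 nM, with an expected range from 4000 nM to 45000 nM.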

Compound 3, half-maximal cytotoxic concentration: > 47300 nM
Compound 3: only a limit was reported (the forecaster's own chance of this, stated with the estimate: 20%); middle value at least 3.3-fold (0.52 log units) away from the limit.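

In this assay compound 3 gives only a limit, not a number: the limit of > 47300 nM in this assay, at which 1 of the 3 values shown sits. The step of an at least 6.9-fold higher number from compound 2 to compound 3 (0.83 log units; beyond the scatter) shows that the number at the amide-type nitrogen can rise well clear of the scatter when the 2-cyanopyridin-4-yl group leaves. The step of an at least 1.6-fold higher number from compound 1 to compound 3 (0.20 log units; that floor lies within the scatter) has a floor within the scatter, so it sets no order between these two compounds.

Still open, going by these compounds, is whether the nitrile or the ring nitrogen of the 2-cyanopyridin-4-yl group goes with the low number of compound 2. A plain phenyl group at this place would separate the two.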